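An Iodophenylamino Analogue of Compound 1

The compounds below may be only part of what the source reports. "The series", "measured", "known", "first", "only" and "open" are said of these compounds alone.

Compound 1 `O=C1C=C(N2CCC2)C(=O)c2c1nc1n2[C@H]2OC[C@@H](O)[C@H]2OC1`: > 16000 nM in a functional assay on HeLa cells (Homo sapiens) for inhibition, read by sulforhodamine B assay; on this read-out lower numbers stand for stronger inhibition and higher numbers for weaker inhibition
Compound 2 `O=C1C(N2CCCC2)=CC(=O)c2c1nc1n2[C@H]2OC[C@@H](O)[C@H]2OC1`: > 16000 nM
Compound 3 `CCOc1ccc(NC2=CC(=O)c3c(nc4n3[C@H]3OC[C@@H](O)[C@H]3OC4)C2=O)cc1`: 14400 nM

Compound 1 stands at the edge of what was measured. In this assay compound 1 gives > 16000 nM, and this is a limit of the assay rather than a number. Compound 2 likewise gives only a limit, > 16000 nM. Compound 1 thus sits on (the limit of > 16000 nM in this assay, at which 2 of the 3 values shown sit). Only compound 3 yields a number, 14400 nM, and that number itself stands for weak inhibition.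

Compound 4 `O=C1C=C(Nc2ccc(I)cc2)C(=O)c2c1nc1n2[C@H]2OC[C@@H](O)[C@H]2OC1` arises from compound 1 by a single change: (4-iodophenyl)amino in place of azetidin-1-yl on a double-bonded ring carbon. Going by the values given here, compound 3, which also carries an arylamino substituent on the shared core, gives the one numeric value. The change is therefore expected to bring compound 4 into the measurable range, by a step estimated as an at least 1.3-fold lower number from compound 1 to compound 4 (0.12 log units; that floor lies within the scatter), at best modest. Compound 4 is therefore expected to give about 12000 nM, in the range 5000 nM to 30000 nM.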

Compound 4, half-maximal inhibitory concentration: 4070 nM
Beside the measured number, compound 4's estimate is 2.9-fold (0.47 log units) above it, and the stated range ends above it.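

In this assay, going by these compounds alone, (4-iodophenyl)amino in place of azetidin-1-yl on a double-bonded ring carbon gives an at least 3.9-fold lower number from compound 1 to compound 4 (0.59 log units; beyond the scatter), so this position now has a step beyond the scatter, which no earlier pair could offer. From the compounds shown here alone, the true size of that step remains unknown, since compound 1 gives a limit and not a number: the limit of > 16000 nM in this assay, at which 2 of the 4 values shown sit. The change shows that this ring carbon tolerates a much larger substituent, an aromatic ring carrying iodine and a hydrogen-bond donor, with a gain in inhibition rather than a loss.

The compounds shown do not separate the contributions of the iodine, the phenyl ring and the amino hydrogen to this step. A plain phenylamino group, a 4-chlorophenylamino group or an N-methyl-N-phenylamino group at this place would bear directly on that question.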